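The source may hold more compounds than are shown below. What is called first, only, known or untested is meant among the compounds shown, and "the series" means these compounds.

Compound 1 `O=S1(=O)NC(NC2CC2)=Nc2cc(Cl)c(Cl)cc21` and compound 2 `O=S1(=O)NC(NC2CCC2)=Nc2cc(Cl)c(Cl)cc21` share one core and differ only in the ring on the amine nitrogen. In a functional assay (aorta) with Rattus norvegicus as the target, with a stated time of 90 min, at 37 degrees C (on this read-out lower numbers stand for an effect already at smaller amounts and higher numbers for an effect only at larger amounts of compound), compound 1 gives only a limit, > 30000 nM, so no number is known for it. In this assay compound 2 gives 12600 nM. For the measured compounds named here, the only measured step is an at least 2.3-fold lower number from compound 1 to compound 2 (0.37 log units; beyond the scatter). Among the values shown, compound 2 holds the only number. The other value shown is the limit of compound 1 (the limit of > 30000 nM in this assay, at which 1 of the 2 values shown sits). Compound 3 `O=S1(=O)NC(NC2CCC2)=Nc2cc(Cl)c(Br)cc21` differs from compound 2 by bromo in place of chloro on an aromatic carbon. Going by the values given here, no measured step changes a halogen on the aromatic ring; the one measured step concerns the ring on the amine nitrogen and so does not bear on this change. The expected step is therefore no larger than the scatter, a 1.3-fold lower number from compound 2 to compound 3 (0.10 log units; within the scatter). On that basis compound 3 is estimated at 10000 nM in this assay, within a range from 4000 nM to 30000 nM.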

Compound 3, half-maximal effective concentration: 6600 nM
The estimate for compound 3 lay 1.5-fold (0.18 log units) above the measured number; low and high end bracket the measured number.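

For the compounds shown here, the only measured change on the aromatic ring turns out small: in this assay, bromo in place of chloro on this aromatic carbon, ortho to a chloro group, gives a 1.9-fold lower number from compound 2 to compound 3 (0.28 log units; within the scatter). At this position, then, the two halogens cannot be told apart on this read-out, and the ring on the amine nitrogen remains the only place with a step shown beyond the scatter. Nothing given here accounts for the size of this step.

The compounds shown leave open how a group other than a halogen, such as methoxy, nitrile or trifluoromethyl, would change the number at this carbon. They also leave open whether a cyclopentyl ring on the amine nitrogen would continue the step seen from cyclopropyl to cyclobutyl.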